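Swapping the Amide for a Phenoxy Group on the Aniline

The source may report more compounds than this note shows. Statements on the series, on what has been measured and on what is new or still open speak of the compounds shown alone.

Measured compounds:
Compound 1, `Nc1ccc(-c2ccc(NC3=CC(=O)c4ncncc4C3=O)cc2)cc1`: in a functional assay on MIA PaCa-2 cells (Homo sapiens) for cytotoxicity, read by MTT assay, with a stated time of 72 h (on this read-out higher numbers stand for weaker inhibition and lower numbers for stronger inhibition), compound 1 gives 2500 nM.
Compound 2, `O=C1C(Nc2ccc(-c3ccc(F)cc3)cc2)=CC(=O)c2ncncc21`: in this assay compound 2 gives 3500 nM.
Compound 3, `NC(=O)c1ccc(NC2=CC(=O)c3ncncc3C2=O)cc1`: in this assay compound 3 gives 8000 nM.

All three share the same core and differ only in the group attached to the aniline ring. Compound 3 has the highest number of the three, and its steps to both other compounds are beyond the scatter, so it is the weakest inhibitor of this small set.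

Compound 4, `O=C1C(Nc2ccc(Oc3ccccc3)cc2)=CC(=O)c2ncncc21`, has not yet been measured. The change from compound 3 is phenoxy in place of carbamoyl on an aromatic carbon.

For the measured compounds named here, two measured steps bear on this. a 3.2-fold higher number from compound 1 to compound 3 (0.51 log units; beyond the scatter) and a 2.3-fold higher number from compound 2 to compound 3 (0.36 log units; beyond the scatter) both show that putting a carbamoyl where a six-membered aromatic ring had stood raised the number by a modest amount. Compound 4 goes the other way: a carbamoyl leaves and a group carrying a six-membered aromatic ring enters at the same place. A modest drop in the number, toward the values of compound 1 and compound 2, is therefore expected.

For compound 4 the estimated value in this assay is 3500 nM, with a range from 1500 nM to 8000 nM. This estimate amounts to an expected step of a 2.3-fold lower number from compound 3 to compound 4 (0.36 log units; beyond the scatter).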

Compound 4, half-maximal inhibitory concentration: 3700 nM
For compound 4 the middle estimate is 1.1-fold (0.02 log units) below the measured one; low and high end bracket the measured number.
By their numbers in this assay, from the lowest: compounds 1, 2 and 4 (each within the scatter of the next); then compound 3.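

In this assay, the step of a 2.2-fold lower number from compound 3 to compound 4 (0.33 log units; beyond the scatter) shows that a six-membered aromatic ring need not be joined directly to the aniline ring for the number to fall below that of the carbamoyl compound, since in phenoxy an oxygen links the two rings. The oxygen link also makes no readable difference against the directly joined rings, with a 1.1-fold higher number from compound 2 to compound 4 (0.02 log units; within the scatter) and a 1.5-fold higher number from compound 1 to compound 4 (0.17 log units; within the scatter) both within the scatter, so compound 3 remains the weakest of the four and the other three cannot be ranked. Nothing shown here accounts for these numbers.

The compounds shown leave open whether the aromatic ring itself matters or whether other groups in place of carbamoyl would give similar numbers, a question that a cyclohexyloxy group, with its saturated ring, or a straight butoxy chain on the same carbon could help to settle. A carboxylic acid at that carbon could likewise show whether compound 3 stands alone or whether other carbonyl-bearing groups share its higher number.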